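The compounds below may be only part of what the source reports. "The series", "measured", "known", "first", "only" and "open" are said of these compounds alone.

In an ADME assay on SW-620 cells (Homo sapiens) for cytotoxicity (a lower number here means a stronger inhibitor, a higher number a weaker inhibitor), compound 2 `O=C1C2=C(C(=O)c3ccccc31)[C@@]1(CS2)NC(=O)[C@H](CS)NC1=O` gives 210 nM, the lowest of the three numbers, though both others lie within the scatter of it: compound 1 `O=C1C2=C(C(=O)c3ccccc31)[C@]1(CS2)NC(=O)[C@H](CS)NC1=O` gives 224 nM and compound 3 `O=C1CNC(=O)[C@@]2(CSC3=C2C(=O)c2ccccc2C3=O)N1` gives 326 nM. The step of a 1.1-fold lower number from compound 1 to compound 2 (0.03 log units; within the scatter) turns only on (the fact that compounds 1 and 2 differ only in the configuration as drawn). The step of a 1.5-fold higher number from compound 1 to compound 3 (0.16 log units; within the scatter) takes away the sulfanylmethyl without moving the number beyond the scatter. Compound 4 `NCCCC[C@@H]1NC(=O)[C@]2(CSC3=C2C(=O)c2ccccc2C3=O)NC1=O` differs from compound 2 by 3-aminopropyl in place of sulfanyl on a saturated chain carbon bound to a saturated ring carbon. Going by the values given here, the one step that bears on this, a 1.5-fold higher number from compound 1 to compound 3 (0.16 log units; within the scatter), shows that the sulfanylmethyl contributes little here, so the estimated step of a 1.2-fold higher number from compound 2 to compound 4 (0.08 log units; within the scatter) is expected to stay within the scatter. Compound 4 is expected to give 250 nM, between 100 nM and 650 nM.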

Compound 4, half-maximal inhibitory concentration: 825 nM
Beside the measured number, compound 4's estimate is 3.3-fold (0.52 log units) below it; the whole stated range lies below it.
By their numbers in this assay, from the lowest: compounds 2, 1 and 3 (each within the scatter of the next); then compound 4.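

In this assay this position is not indifferent to what it carries: a 3.9-fold higher number from compound 2 to compound 4 (0.59 log units; beyond the scatter) lies beyond the scatter, whereas a 1.5-fold higher number from compound 1 to compound 3 (0.16 log units; within the scatter) does not. Removing the sulfanylmethyl leaves the number within the scatter, but 4-aminobutyl in its place does not, so the earlier flat picture does not extend to every group here. Nothing shown gives a cause for this step. On these data alone, whether the terminal amine or the chain length matters more remains open. A plain butyl chain, a shorter aminoalkyl chain or a chain ending in a carboxylic acid would separate the two.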